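The source may hold more compounds than are shown below. What is called first, only, known or untested is meant among the compounds shown, and "the series" means these compounds.

In a functional assay on HepG2 cells (Homo sapiens) for antiproliferative activity, read by MTT assay, with a stated time of 48 h (a higher number here means a weaker inhibitor, a lower number a stronger inhibitor), compound 1 (`CCn1c(C(=O)NCCN)ccc1C(CC)(CC)c1ccc(OCCC(O)(CC)CC)c(C)c1`) gives 1590 nM. Compound 2 (`C#CC(C)OC(=O)c1ccc(C(CC)(CC)c2ccc(OCCC(O)(CC)CC)c(C)c2)n1CC`) is reported only as a limit, > 50000 nM. Compound 3 (`CCn1c(C(=O)Nc2ccc(OC(F)(F)F)cc2)ccc1C(CC)(CC)c1ccc(OCCC(O)(CC)CC)c(C)c1`) is likewise reported only as a limit, > 50000 nM. Compound 3 therefore has no number of its own and stands at the limit of > 50000 nM in this assay, at which 2 of the 3 values shown sit.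

Compound 4 (`CCOC(=O)C(CC(=O)OC)NC(=O)c1ccc(C(CC)(CC)c2ccc(OCCC(O)(CC)CC)c(C)c2)n1CC`) keeps the core of compound 3 and changes only the group on the amide-type nitrogen: a group of 11 heavy atoms (7 carbon, 4 oxygen; no ring) in place of a group of 11 heavy atoms (7 carbon, 1 oxygen, 3 fluorine; one six-membered aromatic ring of carbon only), on an amide-type nitrogen. The aromatic ring leaves, and the group that enters has no ring.

Among the measured compounds shown here, two measured steps bear on this change, and both are large: an at least 31-fold higher number from compound 1 to compound 2 (1.49 log units; beyond the scatter) and an at least 31-fold higher number from compound 1 to compound 3 (1.49 log units; beyond the scatter). Each of them removes the 2-aminoethyl group of compound 1, and compound 4 lacks that group as well. The remaining comparison is a step that the two limits leave unreadable from compound 2 to compound 3, so it offers no size to work from.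

Compound 4 is therefore expected to resemble compound 2 and compound 3 rather than compound 1, with no step beyond the scatter expected in this assay in either direction. For compound 4 the expected step is an at least 1.2-fold lower number from compound 3 to compound 4 (0.09 log units; that floor lies within the scatter). Compound 4 is estimated at 40000 nM, with an expected range from 15000 nM to 100000 nM, and it may well be reported only as a limit.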

Compound 4, half-maximal inhibitory concentration: > 50000 nM
Compound 4: a limit, no number; the forecaster's own chance of this, stated with the estimate: 65%; at least 1.2-fold (0.09 log units) between middle value and limit.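

Replacing the 2-aminoethyl group of compound 1 on the amide-type nitrogen with the ring-free group of 11 heavy atoms gives an at least 31-fold higher number from compound 1 to compound 4 (1.49 log units; beyond the scatter). Among the amides shown, compound 3 had been the only one without the 2-aminoethyl group, and it carries an aromatic ring on that nitrogen, so the earlier compounds could not separate the loss of the 2-aminoethyl group from the arrival of that ring. In this assay compound 4 has no ring in that place and is still reported only as a limit, so the steps from compound 2 and compound 3 to it cannot be read, and the series gathers at one ceiling: the limit of > 50000 nM in this assay, at which 3 of the 4 values shown sit.

Going by these compounds, what stays open is whether the amine of compound 1 or its short chain goes with the measurable value, a question that a 2-hydroxyethyl group on the same nitrogen would address. Also open, on these data alone, is how a longer aminoalkyl chain, or a carboxylic acid in place of the esters of compound 4, would read in this assay.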